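The compounds below may be only part of what the source reports. "The series", "measured", "known", "first", "only" and "open" are said of these compounds alone.

Compound 1: `CCOC(=O)C1=C(N/N=C(/Br)c2ccccc2)Nc2[nH]nc(C)c2C1c1ccc(N(C)C)cc1`, which in a functional assay on HeLa cells (Homo sapiens) for inhibition, read by MTT assay, with a stated time of 48 h (on this read-out lower numbers stand for stronger inhibition and higher numbers for weaker inhibition), gives 75700 nM.
Compound 2: `CCOC(=O)C1=C(N/N=C(\C#N)C(N)=O)Nc2[nH]nc(C)c2C1c1ccc(N(C)C)cc1`, which gives 47300 nM.
Compound 3: `CCOC(=O)C1=C(N/N=C(/C(C)=O)C(=O)OCC)Nc2[nH]nc(C)c2C1c1ccc(N(C)C)cc1`, which reaches only a limit of the assay, > 100000 nM.

All three share one core and differ only in the group on an amine nitrogen. Compound 2 holds the lowest of the two real numbers, but compound 1 sits within the scatter of it, as a 1.6-fold lower number from compound 1 to compound 2 (0.20 log units; within the scatter) shows, so no order between them can be claimed. Compound 3 is a limit and not a number, marked by the limit of > 100000 nM in this assay, at which 1 of the 3 values shown sits.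

Compound 4 is `CCOC(=O)C(=NNC1=C(C(=O)OCC)C(c2ccc(N(C)C)cc2)c2c(C)n[nH]c2N1)C(=O)OCC`. Compared with compound 2 it carries a group of 12 heavy atoms (7 carbon, 1 nitrogen, 4 oxygen; no ring) in place of a group of 7 heavy atoms (3 carbon, 3 nitrogen, 1 oxygen; no ring), on an amine nitrogen. The entering group resembles the group of 10 heavy atoms (6 carbon, 1 nitrogen, 3 oxygen; no ring) in compound 3, which has ester-like oxygens and no ring. The step that bears most on this change is an at least 2.1-fold higher number from compound 2 to compound 3 (0.32 log units; beyond the scatter), while an at least 1.3-fold higher number from compound 1 to compound 3 (0.12 log units; that floor lies within the scatter) has a floor within the scatter. A higher number, likely beyond the scatter, is therefore expected, and a limit is quite possible.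

Compound 4 is expected to give about 100000 nM, in the range 50000 nM to 200000 nM. That estimate means an expected 2.1-fold higher number from compound 2 to compound 4 (0.33 log units; beyond the scatter).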

Compound 4, half-maximal inhibitory concentration: 83800 nM
Beside the measured number, compound 4's estimate is 1.2-fold (0.08 log units) above it; the measured number falls inside the stated range.
By their numbers in this assay, from the lowest: compounds 2, 1 and 4 (each within the scatter of the next). At a limit, above all of these: compound 3.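

In this assay, replacing the group in compound 2, which has a nitrile and no ring, with the no-ring group of 12 heavy atoms gives a 1.8-fold higher number from compound 2 to compound 4 (0.25 log units; within the scatter), and replacing the aromatic-ring group of compound 1 with that same group gives a 1.1-fold higher number from compound 1 to compound 4 (0.04 log units; within the scatter). The amine nitrogen on the double-bonded ring carbon can therefore carry this larger group, which has 0 hydrogen-bond donors and 5 hydrogen-bond acceptors, and still give a real number that cannot be told apart from those of compound 1 and compound 2, so group size sets no visible trend among these three. The remaining step is an at least 1.1-fold lower number from compound 3 to compound 4 (0.07 log units; that floor lies within the scatter), which gives only a floor and settles no order, because compound 3 stands at a limit and not at a number: the limit of > 100000 nM in this assay, at which 1 of the 4 values shown sits.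

From the compounds shown here alone, it remains open whether a different group at this nitrogen, such as an amine, a carboxylic acid or a longer chain, would give a number lower than these by more than the scatter. Going by these compounds, all four compounds share one core, so the effect of changes elsewhere on it also remains open.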